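A few compounds are considered here, and "the series" means these few. Any claim that something is new, unique, unknown or untested is made for them only; others in the source may bear on it.

Compound 1 `COc1cc(C)cc(-c2c(-c3ccnc(-c4ccc(C(C)=O)cc4)c3)cnn2CC#N)c1` was tested in a functional assay on EKVX cells (Homo sapiens) for cytotoxicity, read by sulforhodamine B assay, with a stated time of 48 h, tested at 1 uM (a higher number here means a weaker effect of the compound at the concentration tested, a lower number a stronger effect), where compound 1 gives 37%. For the measured compounds named here, of the two numbers measured so far this is the higher one, yet the gap to the other is small: compound 2 `COc1cc(C)cc(-c2nn(CC#N)cc2-c2ccnc(-c3ccc(N(C)C)cc3)c2)c1` gives 28% in this assay, and that lies within the usual scatter of repeated measurements, so the two compounds cannot be told apart on these data.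

Compound 3 `COc1cc(C)cc(-c2c(-c3ccnc(-c4ccc(N(C)C)cc4)c3)cnn2CC#N)c1` has not yet been measured. It differs from compound 1 in a single place: dimethylamino in place of acetyl on an aromatic carbon. Going by the values given here, no two measured compounds are separated by exactly this change, so there is no measured step to lean on, and the only guide is that both measured compounds sit in the same modest band.

The step of a number 5 percentage points lower from compound 1 to compound 3 (within the scatter) is expected to stay within the scatter, with no clear direction. Compound 3 is therefore estimated to give 32% in this assay, within a range from 15% to 50%.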

Compound 3, a percentage reported as activity, at one concentration (the size of the read-out at that concentration, not a potency): 9%
Beside the measured number, compound 3's estimate is 23 percentage points above it; the measured number lies below the stated range.
By their numbers in this assay, from the lowest: compound 3; then compounds 2 and 1 (each within the scatter of the next).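

In this assay, dimethylamino in place of acetyl gives a step of a number 28 percentage points lower from compound 1 to compound 3 (beyond the scatter), which shows that the number responds to the group carried on this aromatic carbon, para to a large group. The two groups have the same heavy-atom count, and each has one hydrogen-bond acceptor and no donors, so these counts do not separate them; they differ in that a carbonyl-bearing group leaves and a nitrogen-bearing group enters. Nothing measured here accounts for the size of this step.

One pair cannot show whether the lower number is particular to dimethylamino or would also come with another amine, such as pyrrolidine, at this position. It also leaves open where a carboxylic acid or a longer chain on the same carbon would fall.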